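Adding a hexynyl chain to compound 3

The compounds below may be only part of what the source reports. "The series", "measured", "known", "first", "only" and "open" are said of these compounds alone.

Compound 1 `CCCCc1cc2cn(COCCO)c(=O)nc2o1`: > 200000 nM
Compound 2 `CCCCCCCc1cc2cn(COCCO)c(=O)nc2o1`: 140000 nM
Compound 3 `O=c1nc2occc2cn1COCCO`: > 200000 nM

These values come from a functional assay on HEL cells (Homo sapiens); on this read-out higher numbers stand for lower toxicity in this test and lower numbers for higher toxicity in this test. Compound 3 gives > 200000 nM, which is a limit and not a number. Compound 3 therefore stands at the limit of > 200000 nM in this assay, at which 2 of the 3 values shown sit. Compound 1 gives > 200000 nM, which is also a limit.

The next structure is compound 4 `CCCCC#Cc1cc2cn(COCCO)c(=O)nc2o1`, which has not yet been measured. The change is hex-1-yn-1-yl in place of hydrogen on an aromatic carbon. In words, hex-1-yn-1-yl takes the place of hydrogen on an aromatic carbon, next to the ring oxygen.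

The closest measured changes involve butyl and heptyl on the shared core. Removing butyl gives a step that the two limits leave unreadable from compound 1 to compound 3. Removing heptyl gives an at least 1.4-fold higher number from compound 2 to compound 3 (0.15 log units; that floor lies within the scatter). Extending the chain gives an at least 1.4-fold lower number from compound 1 to compound 2 (0.15 log units; that floor lies within the scatter). None of these steps is shown to lie beyond the scatter, so they offer only weak guidance.

Among the measured compounds shown here, compound 2 at 140000 nM is the only chain-bearing compound with a true number, so a long chain is expected to lower the number only slightly. The expected change is an at least 1.3-fold lower number from compound 3 to compound 4 (0.12 log units; that floor lies within the scatter), a modest step that may stay within the scatter. A further limit reading would be no surprise. For compound 4 the estimate is 150000 nM, with an expected range from 70000 nM to 300000 nM.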

Compound 4, half-maximal cytotoxic concentration: > 50000 nM
Compound 4: only a limit was reported; the forecaster's own chance of this, stated with the estimate: 45%; the middle value lies beyond the limit too.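

In this assay compound 4 gives > 50000 nM, which is a limit and not a number. None of the steps from compound 1, compound 2 or compound 3 to compound 4 can be read. The compounds shown leave open whether hex-1-yn-1-yl in place of hydrogen changes the number at all, and how it compares with butyl or heptyl on the shared core.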